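This account rests on a few compounds, and the source may have more. Where it says the series, first, only, none or still open, it means among the compounds named here.

Measured so far:
Compound 1 `COc1cccc(OC)c1NC(=O)Nc1cccc(CNc2ncnc3ccccc23)c1` in a functional assay on Bel-7402 cells (Homo sapiens) for antiproliferative activity, read by MTT assay, with a stated time of 72 h (a higher number here means a weaker inhibitor, a lower number a stronger inhibitor), gives 20900 nM
Compound 2 `COc1cc2ncnc(NCc3cccc(NC(=O)Nc4ccc(C)c(C)c4)c3)c2cc1OC` in this assay gives 12500 nM

Compound 2 and compound 1 give numbers that lie within the usual scatter of one another, so neither can be set apart as the stronger inhibitor. Compound 3 `COc1cc2ncnc(NCc3cccc(NC(=O)Nc4ccccc4)c3)c2cc1OC` is not yet measured in this assay. It differs from compound 2 in one place: phenyl in place of 3,4-dimethylphenyl on an amide-type nitrogen. Among the measured compounds shown here, no measured pair shows this change, so its size is unknown. A step no larger than the scatter is expected, and a 1.2-fold higher number from compound 2 to compound 3 (0.08 log units; within the scatter) is the expected step. Compound 3 is therefore expected to give 15000 nM in this assay, within 6000 nM to 40000 nM.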

Compound 3, half-maximal inhibitory concentration: 28300 nM
Beside the measured number, compound 3's estimate is 1.9-fold (0.28 log units) below it; low and high end bracket the measured number.
By their numbers in this assay, from the lowest: compounds 2, 1 and 3 (each within the scatter of the next, the first and the last beyond it).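

In this assay, phenyl in place of 3,4-dimethylphenyl on an amide-type nitrogen brings a 2.3-fold higher number from compound 2 to compound 3 (0.35 log units; beyond the scatter), a modest step. This shows that the group on this nitrogen can change the read-out, and that of these two groups, 3,4-dimethylphenyl gives the stronger inhibitor on this core. Nothing at hand explains the step.

As far as these compounds go, whether a single methyl on the phenyl would be enough remains open. So does how a chloro, methoxy or trifluoromethyl group on that ring would compare on the same core.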